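Swapping Bromo for Fluoro on Compound 1

The source may report more compounds than this note shows. Statements on the series, on what has been measured and on what is new or still open speak of the compounds shown alone.

In a functional assay on A-431 cells (Homo sapiens) for antiproliferative activity, read by sulforhodamine B assay, with a stated time of 72 h (a lower number here means a stronger inhibitor, a higher number a weaker inhibitor), compound 1 `C=C1CC(CBr)(c2ccccc2)OC1=O` gives 1480 nM. Compound 2 `C=C1C[C@](CBr)(c2ccccc2)OC1=O` gives 1330 nM, and compound 3 `C=C1CC(CBr)(c2ccccc2F)OC1=O` gives 1700 nM. Compound 1 therefore stands within the scatter of both, and the three cannot be ranked.

Compound 4 `C=C1CC(CF)(c2ccccc2)OC1=O` has not yet been measured. It differs from compound 1 as follows: fluoro in place of bromo on a saturated chain carbon bound to a saturated ring carbon. In short, bromomethyl becomes fluoromethyl.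

The measured steps bear on this only indirectly. One is a 1.1-fold lower number from compound 1 to compound 2 (0.05 log units; within the scatter), which concerns only how the configuration is drawn: the fact that one of compounds 1 and 2 is drawn with a defined configuration and the other without, at the place where they differ. The other is a 1.1-fold higher number from compound 1 to compound 3 (0.06 log units; within the scatter), which adds a fluoro on an aromatic carbon. Both stayed within the scatter, but neither touches the bromomethyl group, so they give little guidance and the expectation must stay wide.

The expected change is a modest one, estimated as a 1.7-fold higher number from compound 1 to compound 4 (0.23 log units; within the scatter), and it may not clear the scatter. For compound 4, the estimated value is 2500 nM, with an expected range from 800 nM to 7500 nM.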

Compound 4, half-maximal inhibitory concentration: 25100 nM
The estimate for compound 4 lay 10-fold (1.00 log units) below the measured number, outside the stated range (above it).
By their numbers in this assay, from the lowest: compounds 2, 1 and 3 (each within the scatter of the next); then compound 4.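

In this assay, changing bromomethyl to fluoromethyl gives a 17-fold higher number from compound 1 to compound 4 (1.23 log units; beyond the scatter). Within the data shown here, the earlier steps, one in the drawn configuration and one on an aromatic carbon, stayed within the scatter, so this saturated chain carbon bound to a saturated ring carbon is the first place where a single change moves the number beyond it. Nothing measured on these compounds bears on the reason for this step.

With only bromo and fluoro shown at this place, it stays open whether a chloro, an iodo, a hydroxyl or an amine on the same carbon would sit nearer compound 1 or compound 4. On these data alone, it also stays open whether the same swap would have a similar effect on compound 2 or compound 3.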